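Bromophenyl amide variant on a shared core

This account rests on a few compounds, and the source may have more. Where it says the series, first, only, none or still open, it means among the compounds named here.

Three compounds built on one core carry different aryl groups on the amide nitrogen. Compound 1 `O=C(CSc1nc(Nc2ccccc2)c2ccccc2n1)Nc1ccccc1F` gives 10700 nM in a functional assay on MGC-803 cells (Homo sapiens) for inhibition, read by MTT assay, with a stated time of 72 h; a lower number here means a stronger inhibitor, a higher number a weaker inhibitor. Compound 2 `O=C(CSc1nc(Nc2ccccc2)c2ccccc2n1)Nc1cccc(Cl)c1` gives 14300 nM in this assay, and compound 3 `CCc1cccc(NC(=O)CSc2nc(Nc3ccccc3)c3ccccc3n2)c1` gives 15800 nM. Every step among them stays within the scatter: a 1.3-fold higher number from compound 1 to compound 2 (0.13 log units; within the scatter), a 1.5-fold higher number from compound 1 to compound 3 (0.17 log units; within the scatter) and a 1.1-fold higher number from compound 2 to compound 3 (0.04 log units; within the scatter). Compound 3 therefore stands among the others without any separation that the assay can resolve; its nearest neighbour is compound 2 and its furthest is compound 1, both within the scatter.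

Compound 4 `O=C(CSc1nc(Nc2ccccc2)c2ccccc2n1)Nc1ccc(Br)cc1` differs from compound 3 by 4-bromophenyl in place of 3-ethylphenyl on an amide-type nitrogen. Among the measured compounds shown here, the steps that bear on this change are the aryl swaps from compound 1 to compound 2, from compound 1 to compound 3 and from compound 2 to compound 3, none of which moved the number beyond the scatter. On that basis no step beyond the scatter is expected in this assay for compound 4, and the expected change is a 1.2-fold lower number from compound 3 to compound 4 (0.08 log units; within the scatter). Compound 4 is estimated at 13000 nM, with a range from 6000 nM to 30000 nM.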

Compound 4, half-maximal inhibitory concentration: 19300 nM
Beside the measured number, compound 4's estimate is 1.5-fold (0.17 log units) below it; low and high end bracket the measured number.
By their numbers in this assay, from the lowest: compounds 1, 2, 3 and 4 (each within the scatter of the next).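

In this assay, 4-bromophenyl on the amide-type nitrogen adds a fourth aryl group at this position, and all three new steps stay within the scatter: a 1.2-fold higher number from compound 3 to compound 4 (0.09 log units; within the scatter), a 1.3-fold higher number from compound 2 to compound 4 (0.13 log units; within the scatter) and a 1.8-fold higher number from compound 1 to compound 4 (0.26 log units; within the scatter). The 2-fluorophenyl, 3-chlorophenyl, 3-ethylphenyl and 4-bromophenyl groups therefore give numbers that this assay cannot separate, even with bromine on the ring in place of fluorine, chlorine or ethyl. No measurement at hand speaks to what lies behind these numbers.

Going by these compounds, whether a carboxylic acid or an amine on this aryl ring, or a longer chain in place of the ring, would move the number beyond the scatter remains open. So does whether any change elsewhere on the shared core would do so.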